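The source may report more compounds than this note shows. Statements on the series, on what has been measured and on what is new or still open speak of the compounds shown alone.

Compound 1 `OC[C@]1(O)CO[C@@H](n2cnc3c(NCc4cccc(I)c4)ncnc32)[C@@H]1O`: 45%
Compound 2 `CCNC(=O)[C@@H]1CO[C@@H](n2cnc3c(N)ncnc32)[C@@H]1O`: 10%
Compound 3 `Nc1ncnc2c1ncn2[C@@H]1OC[C@H](CO)[C@H]1O`: 32%

In an assay on CHO cells for displacement of a labelled ligand from adenosine receptor A3 (Homo sapiens), tested at 10 uM (a higher number here means more inhibition at the concentration tested (going by the name of the read-out), a lower number less inhibition), compound 1 gives 45%, the highest of the three numbers. Its nearest neighbour is compound 3, which gives 32%, a gap beyond the usual scatter; compound 2 lies furthest away, with 10%, also beyond the scatter. Compound 4 `OC[C@]1(O)CO[C@@H](n2cnc3c(NCc4cccc(Cl)c4)ncnc32)[C@@H]1O` differs from compound 1 in a single place: chloro in place of iodo on an aromatic carbon. Among the measured compounds shown here, no measured pair among the three shows this kind of change, so there is nothing to read a step from directly. The expectation is a modest fall, of a size close to the edge of the scatter, as the step from compound 1 to compound 4 of a number 13 percentage points lower from compound 1 to compound 4 (beyond the scatter). For compound 4 the estimated value in this assay is 32%, with a range from 12% to 55%.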

Compound 4, a percentage reported as inhibition, at one concentration (the size of the read-out at that concentration, not a potency): 44%
Compound 4: the middle estimate sits 12 percentage points below what was measured; low and high end bracket the measured number.
By their numbers in this assay, from the lowest: compound 2; then compound 3; then compounds 4 and 1 (each within the scatter of the next).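

In this assay, chloro in place of iodo on an aromatic carbon gives a number 1 percentage points lower from compound 1 to compound 4 (within the scatter). Among the compounds shown here, this is the first direct reading at this place on the ring, and at this single concentration the two halogens cannot be told apart. No available evidence bears on why they read alike.

The compounds shown leave open how a methoxy group, an amine or a carboxylic acid would read at this same place. On these data alone, a reading at one concentration is also not a potency, so any difference in potency between compound 1 and compound 4 remains unknown.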